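Quinolin-5-yl replaced by 6-methoxypyridin-3-yl

The source may report more compounds than this note shows. Statements on the series, on what has been measured and on what is new or still open speak of the compounds shown alone.

Measured in a functional assay on MDA-MB-436 cells (Homo sapiens) for antiproliferative activity, read by MTT assay, with a stated time of 48 h; on this read-out higher numbers stand for weaker inhibition and lower numbers for stronger inhibition:
Compound 1 `C=CS(=O)(=O)N1CCN(c2ncnc3sc(-c4ccc(OC)cc4)cc23)CC1`: 28400 nM
Compound 2 `C=CS(=O)(=O)N1CCN(c2ncnc3sc(-c4cccc5ncccc45)cc23)CC1`: 25900 nM

For the measured compounds named here, compound 2, at 25900 nM, stands within the scatter of compound 1, the only other compound measured. Compound 3 `C=CS(=O)(=O)N1CCN(c2ncnc3sc(-c4ccc(OC)nc4)cc23)CC1` differs from it as follows: 6-methoxypyridin-3-yl in place of quinolin-5-yl on an aromatic carbon. Going by the values given here, the one measured step that bears on this change, a 1.1-fold lower number from compound 1 to compound 2 (0.04 log units; within the scatter), put quinolin-5-yl in place of 4-methoxyphenyl on the same aromatic carbon. Nothing beyond the scatter is therefore expected in this assay. The estimated change is a 1.0-fold higher number from compound 2 to compound 3 (0.02 log units; within the scatter). For compound 3 the estimate is 27000 nM, expected to fall between 12000 nM and 60000 nM.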

Compound 3, half-maximal inhibitory concentration: 11900 nM
For compound 3 the middle estimate is 2.3-fold (0.36 log units) above the measured one; the measured number lies below the stated range.
By their numbers in this assay, from the lowest: compound 3; then compounds 2 and 1 (each within the scatter of the next).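

In this assay, the aromatic carbon next to the ring sulfur now proves able to shift the number: 6-methoxypyridin-3-yl gives a 2.2-fold lower number from compound 2 to compound 3 (0.34 log units; beyond the scatter) and a 2.4-fold lower number from compound 1 to compound 3 (0.38 log units; beyond the scatter), both modest but beyond the scatter, whereas the earlier exchange of 4-methoxyphenyl for quinolin-5-yl moved nothing beyond it. No measurement shown accounts for this difference.

Going by these compounds, it remains open whether the ring nitrogen or the methoxy group matters more, and whether an amine or a longer alkoxy chain in place of that methoxy would lower the number further.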